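Series notes: aryl swap on the ring nitrogen of compound 3

A few compounds are considered here, and "the series" means these few. Any claim that something is new, unique, unknown or untested is made for them only; others in the source may bear on it.

Three members of the series have been run in a functional assay on A549 cells (Homo sapiens) for inhibition, read by MTT assay, with a stated time of 48 h; on this read-out lower numbers stand for stronger inhibition and higher numbers for weaker inhibition. Compound 1 `COc1cccc(-n2cc(NC(=O)c3cccc(NS(=O)(=O)c4ccccc4)c3)cn2)c1` gives 81100 nM. Compound 2 `O=C(Nc1cnn(-c2ccccc2)c1)c1cccc(NS(=O)(=O)c2ccc(Cl)cc2)c1` gives 19300 nM, and compound 3 `Cc1ccc(-n2cc(NC(=O)c3cccc(NS(=O)(=O)c4ccc(Cl)cc4)c3)cn2)cc1` gives 15600 nM. Compound 3 and compound 2 lie within the scatter of each other, the measured step being a 1.2-fold lower number from compound 2 to compound 3 (0.09 log units; within the scatter); compound 1 sits well apart from both, its number being beyond the scatter from that of compound 3.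

Compound 4 `COc1cccc(-n2cc(NC(=O)c3cccc(NS(=O)(=O)c4ccc(Cl)cc4)c3)cn2)c1` has not yet been measured. It differs from compound 3 by 3-methoxyphenyl in place of 4-methylphenyl on an aromatic nitrogen. For the measured compounds named here, no measured step covers this exchange on its own. Compound 1 carries the same 3-methoxyphenyl as compound 4 but an unsubstituted phenyl on the sulfonyl, so compound 1 and compound 3 differ in two places at once, and it is not known how much of that gap belongs to the aryl on the ring nitrogen. Going by the values given here, the only single step available, a 1.2-fold lower number from compound 2 to compound 3 (0.09 log units; within the scatter), concerns a different exchange and is within the scatter.

Compound 4 is therefore expected to fall between the numbers of compound 3 and compound 1, with the step of a 2.2-fold higher number from compound 3 to compound 4 (0.35 log units; beyond the scatter) estimated as a modest rise. The estimate for compound 4 in this assay is 35000 nM, with a range from 12000 nM to 100000 nM.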

Compound 4, half-maximal inhibitory concentration: 44400 nM
Compound 4: middle estimate off by 1.3-fold (0.10 log units), on the low side; measured number inside the range.
By their numbers in this assay, from the lowest: compounds 3 and 2 (each within the scatter of the next); then compounds 4 and 1 (each within the scatter of the next).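

Working notes on the aryl at the ring nitrogen: in this assay, the exchange of 4-methylphenyl for 3-methoxyphenyl on the aromatic nitrogen of the five-membered ring now has a measured size of its own, a 2.8-fold higher number from compound 3 to compound 4 (0.45 log units; beyond the scatter). Starting from the unsubstituted phenyl, the two substituents read differently: the methoxy exchange gives a 2.3-fold higher number from compound 2 to compound 4 (0.36 log units; beyond the scatter), whereas the methyl exchange gave only a 1.2-fold lower number from compound 2 to compound 3 (0.09 log units; within the scatter), so this position does respond to what the phenyl carries, at least for 3-methoxyphenyl. At the far end of the molecule, with 3-methoxyphenyl held constant, the chloro exchange on the aryl at the sulfonyl gives a 1.8-fold lower number from compound 1 to compound 4 (0.26 log units; within the scatter), so that exchange shows no effect that can be told from the scatter in this pair.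

No measurement at hand explains any of these steps. Still open, as far as these compounds go, is whether the step follows the methoxy group itself or where the substituent stands on the phenyl, as the two change together between compound 3 and compound 4, and how this position would answer to a phenyl bearing an amine or a carboxylic acid.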